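Diacylhydrazine ecdysone agonists: a cyano substituent on the benzoyl ring

The compounds below may be only part of what the source reports. "The series", "measured", "known", "first", "only" and "open" are said of these compounds alone.

Measured compounds:
compound 1, `CC(C)(C)N(NC(=O)c1ccccc1)C(=O)c1ccccc1Br`, 170 nM
compound 2, `Cc1ccccc1C(=O)N(NC(=O)c1ccccc1)C(C)(C)C`, 224 nM
compound 3, `CC(C)(C)N(NC(=O)c1ccccc1Br)C(=O)c1ccccc1Cl`, 316 nM

The three compounds share a tert-butyl-substituted diacylhydrazine core and were tested in an assay on cells for agonist activity at ecdysone receptor (Bombyx mori), read by a luciferase reporter, with a stated time of 24 h; a higher number here means that more compound is needed for the effect, a lower number that less compound is needed. Compound 3 gives 316 nM, while compound 2 gives 224 nM and compound 1 gives 170 nM; the gaps from compound 3 to both other compounds fall within the scatter, so the three numbers cannot be told apart.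

Compound 4, `CC(C)(C)N(NC(=O)c1cccc(C#N)c1)C(=O)c1ccccc1Cl`, has not been measured. It differs from compound 3 in one place: 3-cyanophenyl in place of 2-bromophenyl on a carbonyl carbon. Among the compounds with values here, the only measured single step, a 1.3-fold higher number from compound 1 to compound 2 (0.12 log units; within the scatter), concerns a methyl in place of bromo on the other benzoyl ring and was within the scatter, so it does not bear directly on the present change. Compounds 1 and 3 differ in two places and their values are likewise within the scatter of each other. Nothing measured here speaks for a large shift in either direction.

Compound 4 is therefore expected to show a 1.3-fold higher number from compound 3 to compound 4 (0.10 log units; within the scatter), a step not expected to exceed the scatter. The estimate for compound 4 in this assay is 400 nM, with a range from 150 nM to 1200 nM.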

Compound 4, half-maximal effective concentration: 955 nM
Compound 4: middle estimate off by 2.4-fold (0.38 log units), on the low side; the range from low to high includes it.
By their numbers in this assay, from the lowest: compounds 1, 2 and 3 (each within the scatter of the next); then compound 4.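

In this assay, the exchange of 2-bromophenyl for 3-cyanophenyl on a carbonyl carbon gives a 3.0-fold higher number from compound 3 to compound 4 (0.48 log units; beyond the scatter) and so is the first change among these compounds to move the number beyond the scatter, whereas the earlier step, methyl in place of bromo on an aromatic carbon, gave only a 1.3-fold higher number from compound 1 to compound 2 (0.12 log units; within the scatter) and could not be told from repeat measurements. The result shows that the group on this carbonyl carbon, whose other neighbour is the amide-type nitrogen, cannot be exchanged freely, as this one change alone calls for more compound to reach the effect. No available evidence bears on why the number rises with this change.

With a single step at this place, the compounds shown leave open whether the rise goes with the loss of the bromine, the arrival of the nitrile, or the different placement implied by the two group names. They also leave open how 2-cyanophenyl, 3-bromophenyl or 3-aminophenyl on the same carbonyl carbon would compare with the two groups seen here.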